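This account rests on a few compounds, and the source may have more. Where it says the series, first, only, none or still open, it means among the compounds named here.

Two compounds of the series carry numbers in a functional assay on NCI-H226 cells (Homo sapiens) for inhibition; a lower number here means a stronger inhibitor of growth, a higher number a weaker inhibitor of growth. Compound 1 `COc1cc(/C=C/C(=O)c2cccc(-n3cc(-c4ccccc4)[nH]c3=O)c2)ccc1O` gives 2600 nM. Among the measured compounds shown here, compound 2 `O=C(/C=C/c1cccc(O)c1)c1cccc(-n2cc(-c3ccccc3)[nH]c2=O)c1` gives 24800 nM, the higher of the two, the only step so far being a 9.5-fold higher number from compound 1 to compound 2 (0.98 log units; beyond the scatter), on the hydroxyphenyl end of the chain. Compound 3 `O=C(/C=C/c1cccc(O)c1)c1cccc(-n2cc(-c3ccc(Cl)cc3)[nH]c2=O)c1` differs from compound 2 by chloro in place of hydrogen on an aromatic carbon, para to a large group; read one bond further out this is phenyl to 4-chlorophenyl. For the measured compounds named here, no measured step touches that ring, so the expected step of a 1.2-fold lower number from compound 2 to compound 3 (0.09 log units; within the scatter) in this assay is none beyond the scatter. Compound 3 is estimated at 20000 nM, within 6000 nM to 60000 nM.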

Compound 3, concentration for 50% growth inhibition: 2310 nM
Estimate against measurement, compound 3: 8.7-fold (0.94 log units) above; measured number below the stated range.
By their numbers in this assay, from the lowest: compounds 3 and 1 (each within the scatter of the next); then compound 2.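

Among the compounds shown here, the phenyl ring of the core responds to substitution: in this assay chloro on an aromatic carbon, para to a large group, gives an 11-fold lower number from compound 2 to compound 3 (1.03 log units; beyond the scatter) and is the first measured change at this ring. With the hydroxyphenyl end held as the 3-hydroxyphenyl of compound 2, one chlorine atom is enough for a step beyond the scatter. No available measurement explains this step.

Still open, going by these compounds, is whether bromo, methoxy or an amine at this carbon would give a similar step. On these data alone, it is also open whether chloro would do the same with the 4-hydroxy-3-methoxyphenyl end of compound 1.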